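Removing the Ethyl Branch in a Carbamate FAAH Inhibitor

The compounds below may be only part of what the source reports. "The series", "measured", "known", "first", "only" and "open" are said of these compounds alone.

Compound 1 `CCCCOc1ccc(C(CC)NC(=O)Oc2ccccc2F)cc1`: 7.7 nM
Compound 2 `CCCCOc1ccc(C(CC)NC(=O)Oc2cccc(N(C)C)c2)cc1`: 54 nM
Compound 3 `CCCCOc1ccc(C(CC)NC(=O)Oc2ccc(F)cc2)cc1`: 12 nM

In an assay on H4 cells for inhibition of Fatty-acid amide hydrolase 1 (Homo sapiens) (a higher number here means a weaker inhibitor, a lower number a stronger inhibitor), compound 1 gives the lowest of the three numbers. Compound 3 sits within the scatter of compound 1 (a 1.6-fold higher number from compound 1 to compound 3 (0.19 log units; within the scatter)), while compound 2 lies clearly further off (a 7.0-fold higher number from compound 1 to compound 2 (0.85 log units; beyond the scatter)). Compound 4 `CCCCOc1ccc(CNC(=O)Oc2ccccc2F)cc1` differs from compound 1 by hydrogen in place of ethyl on a saturated chain carbon bound to an amide-type nitrogen and an aromatic carbon. Every measured step swaps the aryl group on the oxygen and leaves this chain carbon untouched, so none of them speaks to the size or direction of this change. Among the measured compounds shown here, with no comparable step to lean on, the expectation for compound 4 is a number near that of compound 1, but with a wide range. The estimate for compound 4 is 30 nM, expected to fall between 5 nM and 200 nM. The step this estimate implies is a 3.9-fold higher number from compound 1 to compound 4 (0.59 log units; beyond the scatter).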

Compound 4, half-maximal inhibitory concentration: 9.2 nM
Compound 4: middle estimate off by 3.3-fold (0.51 log units), on the high side, and the stated range covers the measured number.
By their numbers in this assay, from the lowest: compounds 1, 4 and 3 (each within the scatter of the next); then compound 2.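

In this assay hydrogen in place of ethyl on this saturated chain carbon (a 1.2-fold higher number from compound 1 to compound 4 (0.08 log units; within the scatter)) stays within the scatter. Among the compounds shown here, this is the first measured change at this position, and it shows that, with 2-fluorophenyl on the oxygen, the ethyl branch can go without a clear shift in the number. Nothing available bears on the reason for this result. From the compounds shown here alone, whether the same holds with 4-fluorophenyl or 3-(dimethylamino)phenyl on the oxygen remains open, as does the effect of a longer chain or an amine on this carbon.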